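A few compounds are considered here, and "the series" means these few. Any claim that something is new, unique, unknown or untested is made for them only; others in the source may bear on it.

Measured compounds:
compound 1 `N#C/N=C1\N(CCCCCOc2ccc(Cl)cc2)C(=O)CN1c1ccncc1`: 3400 nM
compound 2 `N#C/N=C1\N(CCCCCCOc2ccc(Cl)cc2)C(=O)CN1c1ccncc1`: 2960 nM

Both compounds were tested in a functional assay on HONE1 cells for cytotoxicity against HONE1 cell line (Homo sapiens) (a higher number here means a weaker inhibitor, a lower number a stronger inhibitor), where compound 1 gives 3400 nM and compound 2 gives 2960 nM. For the measured compounds named here, these two numbers sit within the scatter of each other, so nothing separates compound 2 from compound 1 on the evidence so far; the one measured step, a 1.1-fold lower number from compound 1 to compound 2 (0.06 log units; within the scatter), came from lengthening the saturated chain by one carbon.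

Compound 3 `N#C/N=C1\N(CCCCCCCOc2ccc(Cl)cc2)C(=O)CN1c1ccncc1` continues in the same direction: the change is (4-chlorophenoxy)methyl in place of 4-chlorophenoxy on a saturated chain carbon, six bonds along the chain from an amide-type nitrogen in a ring. Going by the values given here, the only measured step that bears on this is the step from compound 1 to compound 2, which was the same kind of chain lengthening one bond closer to the ring and produced a difference well inside the scatter. With a single comparable step of that size, no movement beyond the scatter is expected in this assay for compound 3, in either direction. The step from compound 2 to compound 3 is estimated as a 1.1-fold lower number from compound 2 to compound 3 (0.02 log units; within the scatter). Compound 3 is accordingly expected to give about 2800 nM, with a range from 1300 nM to 6000 nM.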

Compound 3, half-maximal inhibitory concentration: 3240 nM
Estimate against measurement, compound 3: 1.2-fold (0.06 log units) below, within the range that was stated.
By their numbers in this assay, from the lowest: compounds 2, 3 and 1 (each within the scatter of the next).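

In this assay, (4-chlorophenoxy)methyl in place of 4-chlorophenoxy, six bonds along the chain from an amide-type nitrogen in a ring, gives a 1.1-fold higher number from compound 2 to compound 3 (0.04 log units; within the scatter) and so repeats the lack of a readable effect seen one bond closer to the ring. The new comparison over a wider change, 2-(4-chlorophenoxy)ethyl in place of 4-chlorophenoxy, five bonds along the chain from an amide-type nitrogen in a ring, gives a 1.0-fold lower number from compound 1 to compound 3 (0.02 log units; within the scatter), which shows that the small steps do not add up to a real difference across these three compounds. Nothing measured alongside these numbers offers an explanation for this flat result.

The compounds shown leave open whether a much shorter or much longer chain would move the number beyond the scatter, since all three lengths here sit close together. They also leave open what would happen if the chlorine on the far aromatic ring gave way to a trifluoromethyl group, or if the ether oxygen in the chain gave way to an amine.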